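Swapping Isopropyl for Carbamoylmethyl at the Chain End

The source may hold more compounds than are shown below. What is called first, only, known or untested is meant among the compounds shown, and "the series" means these compounds.

Compound 1 `CCCC(=O)OCSc1ccccc1C(=O)N[C@H]1CCC[C@H]1C(N)=O` measures 89.9 uM; 84.8 uM (2 entries) across its entries
Compound 2 `CCCC(=O)OCSc1ccccc1C(=O)NCC(=O)NC(C)C` measures 92 uM in its one numbered entry

Among the measured compounds shown here, in an ADME assay on CEM-SS cells (Homo sapiens) for cytotoxicity, read by XTT assay, with a stated time of 6 days (on this read-out lower numbers stand for higher toxicity in this test and higher numbers for lower toxicity in this test), compound 2 stands at 92 uM as its only number, and one further entry for it gives no single number. Compound 3 `CCCC(=O)OCSc1ccccc1C(=O)NCC(=O)NCC(N)=O` keeps the shared core but changes the end of the chain: carbamoylmethyl in place of isopropyl on an amide-type nitrogen. For the measured compounds named here, no measured pair isolates this change, so the evidence is thin. Compound 1 at 89.9 uM; 84.8 uM (2 entries) and compound 2 at 92 uM lie within the usual scatter of each other, although their chains differ, so nothing beyond the scatter is expected here. The expected change, a 1.0-fold lower number from compound 2 to compound 3 (0.01 log units; within the scatter), is therefore small. For compound 3 the estimated value is 90 uM, with an expected range from 45 uM to 180 uM in this assay.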

Compound 3, half-maximal toxic concentration: > 100 uM
Compound 3 was reported as a limit; the forecaster's own chance of this, stated with the estimate: 45%; middle value at least 1.1-fold (0.04 log units) away from the limit.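

In this assay compound 3 gives > 100 uM, which is a limit and not a number. Putting carbamoylmethyl in place of isopropyl on an amide-type nitrogen gives an at least 1.0-fold higher number from compound 2 to compound 3 (0.03 log units; that floor lies within the scatter), the only step shown that isolates a change at this position. The step shows no move toward lower numbers, so this swap brings no sign of higher toxicity in this test, although its true size cannot be read from a limit: the limit of > 100 uM in this assay, at which 1 of the 3 values shown sits.

As far as these compounds go, how the chain end would fare with an amine, a carboxylic acid or a longer chain in this position remains open. Also open is whether any group here can bring the number clearly down from that of compound 2, since the one step shown stays within the usual scatter at its floor.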